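The source may report more compounds than this note shows. Statements on the series, on what has been measured and on what is new or still open speak of the compounds shown alone.

Of the compounds shown here, three on the shared core have been measured: compound 1 `COc1cccc(-c2nc(SC)nc3sc(C(=O)NCc4ccccc4)c(N)c23)c1`, compound 2 `CCOC(=O)c1sc2nc(SC)nc(-c3cccc(OC)c3)c2c1N` and compound 3 `COc1cccc(-c2nc(SC)nc3sc(C(=O)NN)c(N)c23)c1`. In a functional assay on HEK293 cells for agonist activity at lutropin-choriogonadotropic hormone receptor (Homo sapiens), read by cAMP accumulation (on this read-out lower numbers stand for smaller maximal responses and higher numbers for larger maximal responses), compound 1 gives 7.8%, compound 2 gives 4.2% and compound 3 gives 8.5%. The step of a number 3.6 percentage points lower from compound 1 to compound 2 (within the scatter) exchanges benzylamino for ethoxy on the carbonyl carbon; the step of a number 0.7 percentage points higher from compound 1 to compound 3 (within the scatter) puts amino in place of benzyl on the amide-type nitrogen; the step of a number 4.3 percentage points higher from compound 2 to compound 3 (within the scatter) puts aminoamino in place of ethoxy on the carbonyl carbon. Compound 3 carries the highest of the three numbers, yet both of its steps to the others lie within the scatter, so no ordering among the three is supported.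

Compound 4 `CCNC(=O)c1sc2nc(SC)nc(-c3cccc(OC)c3)c2c1N` is the next member. Its difference from compound 3 is ethyl in place of amino on an amide-type nitrogen. Within the data shown here, the steps that bear on this site are a number 0.7 percentage points higher from compound 1 to compound 3 (within the scatter) and a number 4.3 percentage points higher from compound 2 to compound 3 (within the scatter), both within the scatter, and no substituent on this nitrogen has yet shifted the read-out. The step from compound 3 to compound 4 is therefore expected to be small, a number 1.5 percentage points lower from compound 3 to compound 4 (within the scatter). Compound 4 is estimated at 7%, with a range from 2% to 13%.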

Compound 4, largest response reached (reported as efficacy), in percent of the reference or control that the assay uses: 26.9%
Compound 4: middle estimate off by 19.9 percentage points, on the low side; measured number outside the range, above it.
By their numbers in this assay, from the lowest: compounds 2, 1 and 3 (each within the scatter of the next); then compound 4.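

In this assay, among these compounds, the group on the amide-type nitrogen does shift the read-out: ethyl in place of amino gives the first step beyond the scatter (a number 18.4 percentage points higher from compound 3 to compound 4 (beyond the scatter)). The same holds on the carbonyl carbon, where ethylamino in place of ethoxy gives a step of similar standing (a number 22.7 percentage points higher from compound 2 to compound 4 (beyond the scatter)), and on the saturated chain carbon bound to the amide-type nitrogen, where methyl in place of phenyl also clears the scatter (a number 19.1 percentage points higher from compound 1 to compound 4 (beyond the scatter)). Compound 4 thus stands apart from compounds 1, 2 and 3, which remain within the scatter of one another, and nothing measured here speaks to why.

Going by these compounds, whether the response depends on chain length remains open: a methyl or a propyl chain on this nitrogen would test that. Also open, on these data alone, is whether the amide hydrogen is needed, which a dimethylamino group on the carbonyl carbon would address.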